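This account rests on a few compounds, and the source may have more. Where it says the series, first, only, none or still open, it means among the compounds named here.

Compound 1 `COc1ccc(-c2nn(-c3ccccc3)cc2C(=O)/C=C\Nc2ccc(F)cc2)cc1` carries a fluoro group on an aromatic carbon and, in a functional assay on PC-3 cells (Homo sapiens) for antiproliferative activity, read by MTT assay, with a stated time of 48 h (on this read-out higher numbers stand for weaker inhibition and lower numbers for stronger inhibition), compound 1 gives 5730 nM. Compound 2 `COc1ccc(-c2nn(-c3ccccc3)cc2C(=O)/C=C\Nc2ccc(C(F)(F)F)cc2)cc1` bears a trifluoromethyl in the same place. In this assay compound 2 reaches only a limit of the assay, > 50000 nM, with no number beyond it (the limit of > 50000 nM in this assay, at which 1 of the 2 values shown sits). Going by the values given here, the one measured step, an at least 8.7-fold higher number from compound 1 to compound 2 (0.94 log units; beyond the scatter), thus sets compound 2 at the weak end of the two values shown. Compound 3 `COc1ccc(-c2nn(-c3ccccc3)cc2C(=O)/C=C\Nc2ccc(O)cc2)cc1` is reached by a further change in that place: hydroxy in place of trifluoromethyl on an aromatic carbon. Among the compounds with values here, no measured step involves a hydroxy group, so the only bearing comes from an at least 8.7-fold higher number from compound 1 to compound 2 (0.94 log units; beyond the scatter), which shows that the trifluoromethyl weakened inhibition relative to fluoro. Removing it is expected to bring the number back down, and the expected step is an at least 5.0-fold lower number from compound 2 to compound 3 (0.69 log units; beyond the scatter). Compound 3 is therefore estimated to give 10000 nM, within 3000 nM to 50000 nM.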

Compound 3, half-maximal inhibitory concentration: 1980 nM
Estimate against measurement, compound 3: 5.1-fold (0.70 log units) above; the measured number lies below the stated range.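

In this assay the step of a 2.9-fold lower number from compound 1 to compound 3 (0.46 log units; beyond the scatter) shows that hydroxy, on this aromatic carbon para to a large group, gives stronger inhibition than fluoro, so this place allows a gain as well as the loss seen with trifluoromethyl. The step of an at least 25-fold lower number from compound 2 to compound 3 (1.40 log units; beyond the scatter) carries the number past that of compound 1, and the three groups now span both directions from fluoro. The full size of that step cannot be read, and the value of compound 2 is a limit and not a number: the limit of > 50000 nM in this assay, at which 1 of the 3 values shown sits.

The compounds shown leave open whether a methoxy or an amino group in this place would sit nearer to hydroxy or to fluoro. They also leave open whether a carboxylic acid here would carry the gain further.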